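A second methoxy on compound 2

A few compounds are considered here, and "the series" means these few. Any claim that something is new, unique, unknown or untested is made for them only; others in the source may bear on it.

Compound 1 `Cc1ccccc1-c1cc(-c2ccccc2O)nc(O)c1C#N`: 1000 nM
Compound 2 `COc1ccccc1-c1cc(-c2ccccc2O)nc(O)c1C#N`: 12 nM

In a functional assay (aorta) with Rattus norvegicus as the target (a higher number here means a weaker inhibitor, a lower number a stronger inhibitor), compound 2 holds the lower of the two numbers. Going by the values given here, the one measured step, an 83-fold lower number from compound 1 to compound 2 (1.92 log units; beyond the scatter), is large, but it put methoxy in place of methyl. Compound 3 `COc1ccc(-c2cc(-c3ccccc3O)nc(O)c2C#N)c(OC)c1` differs from compound 2 in a different way: methoxy in place of hydrogen on an aromatic carbon. Among the compounds with values here, it has methoxy in place of hydrogen on an aromatic carbon, so no measured step gives this size directly. A modest move toward a higher number is expected, and the expected step is a 2.1-fold higher number from compound 2 to compound 3 (0.32 log units; beyond the scatter). Compound 3 is estimated at 25 nM, with an expected range of 5 nM to 120 nM.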

Compound 3, half-maximal inhibitory concentration: 380 nM
Compound 3: the middle estimate sits 15-fold (1.18 log units) below what was measured, and the stated range ends below it.
By their numbers in this assay, from the lowest: compound 2; then compound 3; then compound 1.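

In this assay, a methoxy on the aromatic carbon para to a large group and meta to a methoxy group gives a 32-fold higher number from compound 2 to compound 3 (1.50 log units; beyond the scatter) and so shows that this carbon is sensitive to substitution. Methoxy for methyl had lowered the number, whereas this methoxy for hydrogen raises it, so a methoxy does not act in one direction wherever it is placed. Nothing available accounts for the rise. From the compounds shown here alone, whether a fluorine, a hydroxyl or an amine on this carbon would also raise the number stays open. So does whether the rise comes from methoxy itself or from any group at this position.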